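The source may hold more compounds than are shown below. What is called first, only, known or untested is meant among the compounds shown, and "the series" means these compounds.

Series overview:
compound 1 `CNCc1ccc(-n2c(SC(C)c3ccccc3)nc3c(cnn3C)c2=O)cc1`: in an assay on isolated protein for inhibition of Retinaldehyde dehydrogenase 3 (Homo sapiens), tested at 5 uM (a higher number here means more inhibition at the concentration tested (going by the name of the read-out), a lower number less inhibition), compound 1 gives 57%
compound 2 `COc1ccc(C(C)Sc2nc3c(cnn3C)c(=O)n2-c2ccccc2)cc1`: in this assay compound 2 gives 39%
compound 3 `CC(Sc1nc2c(cnn2C)c(=O)n1-c1ccc(CN(C)C)cc1)c1ccccc1`: in this assay compound 3 gives 53%

Compound 2 stands lowest of the three in this assay, beyond the scatter against both compound 3 and compound 1. Going by the values given here, the only measured step, a number 4 percentage points lower from compound 1 to compound 3 (within the scatter), lies within the scatter and concerns the amine nitrogen, not the chain carbon.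

Compound 4 `CC(Sc1nc2c(cnn2C)c(=O)n1-c1ccccc1)c1ccncc1` differs from compound 2 by pyridin-4-yl in place of 4-methoxyphenyl on a saturated chain carbon bound to a saturated chain carbon and a sulfur. Among the compounds with values here, no measured step touches this position, so the size and direction of the change in this assay cannot be read from the series; no step beyond the scatter is expected in either direction. Compound 4 is therefore estimated at 42%, range 20% to 62%, which means an expected step of a number 3 percentage points higher from compound 2 to compound 4 (within the scatter).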

Compound 4, a percentage reported as inhibition, at one concentration (the size of the read-out at that concentration, not a potency): 45%
For compound 4 the middle estimate is 3 percentage points below the measured one; low and high end bracket the measured number.
By their numbers in this assay, from the lowest: compounds 2, 4, 3 and 1 (each within the scatter of the next, the first and the last beyond it).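

Pyridin-4-yl in place of 4-methoxyphenyl gives a number 6 percentage points higher from compound 2 to compound 4 (within the scatter) in this assay, the first measured step at this position. The read-out at this position therefore survives the exchange of a carbon-only aromatic ring for one with a hetero atom, with no change beyond the scatter. Nothing available explains this result.

Still open, as far as these compounds go, is whether pyridin-3-yl, cyclohexyl or a phenyl ring carrying a carboxylic acid at this position would shift the read-out beyond the scatter. Also open, from the compounds shown here alone, is whether the step holds when the other aromatic ring carries the amine of compound 1 or compound 3.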